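Amino replacing aminopiperidinyl at the aryl position

This account rests on a few compounds, and the source may have more. Where it says the series, first, only, none or still open, it means among the compounds named here.

Within the data shown here, compound 3 `Cc1cc(N2CCC(N)CC2)c(S(C)(=O)=O)cc1C(=O)N=C(N)N` gives 9.8 nM in a functional assay for inhibition of sodium/hydrogen exchanger (Oryctolagus cuniculus) (on this read-out lower numbers stand for stronger inhibition and higher numbers for weaker inhibition), the lowest of the three numbers so far, although it cannot be ordered against compound 2 `Cc1cc(Oc2ccccc2)c(S(C)(=O)=O)cc1C(=O)N=C(N)N`, which gives 10 nM, since a 1.0-fold lower number from compound 2 to compound 3 (0.01 log units; within the scatter) lies within the scatter. Compound 1 `Cc1cc(Cl)c(S(C)(=O)=O)cc1C(=O)N=C(N)N` gives 25 nM; the steps of a 2.6-fold lower number from compound 1 to compound 3 (0.41 log units; beyond the scatter) and a 2.5-fold lower number from compound 1 to compound 2 (0.40 log units; beyond the scatter) are both beyond the scatter.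

Compound 4 `Cc1cc(N)c(S(C)(=O)=O)cc1C(=O)N=C(N)N` differs from compound 3 by amino in place of 4-aminopiperidin-1-yl on an aromatic carbon. Among the measured compounds shown here, no measured step places an amino group at this position. For the measured compounds named here, the steps that bear on it are a 2.6-fold lower number from compound 1 to compound 3 (0.41 log units; beyond the scatter), where chloro gave the higher number, and a 1.0-fold lower number from compound 2 to compound 3 (0.01 log units; within the scatter), where two larger groups were indistinguishable. Amino, like chloro, is a small group, whereas phenoxy and 4-aminopiperidin-1-yl are large, so a modest rise in the number back toward that of compound 1 is expected, with wide uncertainty. The estimate for compound 4 in this assay is 20 nM, range 8 nM to 60 nM, an expected step of a 2.0-fold higher number from compound 3 to compound 4 (0.31 log units; beyond the scatter).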

Compound 4, half-maximal inhibitory concentration: 16 nM
Beside the measured number, compound 4's estimate is 1.3-fold (0.10 log units) above it; measured number inside the range.
By their numbers in this assay, from the lowest: compounds 3, 2, 4 and 1 (each within the scatter of the next, the first and the last beyond it).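

In this assay, amino at this place, ortho to a methylsulfonyl group, cannot be separated from either large group: a 1.6-fold higher number from compound 3 to compound 4 (0.21 log units; within the scatter) and a 1.6-fold higher number from compound 2 to compound 4 (0.20 log units; within the scatter) both lie within the scatter, so going from 7 heavy atoms in 4-aminopiperidin-1-yl to 1 heavy atom in amino brings no readable change. Amino also cannot be separated from chloro, with a 1.6-fold lower number from compound 1 to compound 4 (0.19 log units; within the scatter) within the scatter, so compound 4 falls inside the gap of a 2.6-fold lower number from compound 1 to compound 3 (0.41 log units; beyond the scatter) without resolving from either end of it. No supporting data are available to explain these numbers.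

From the compounds shown here alone, it remains open whether a carboxylic acid or a longer chain ending in an amine at this place would shift the number beyond the scatter. Methylamino and dimethylamino would test whether small changes to amino can be told apart.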